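Phenyl to ethynyl on two nucleoside cores: working notes

The source may hold more compounds than are shown below. What is called first, only, known or untested is meant among the compounds shown, and "the series" means these compounds.

Compound 1 `Cc1nc(N)c2c(-c3ccccc3)cn([C@@H]3O[C@H](CO)[C@@H](O)[C@H]3O)c2n1`: in a functional assay on K562 cells (Homo sapiens), read by MTT assay, with a stated time of 72 h (a higher number here means a weaker inhibitor, a lower number a stronger inhibitor), compound 1 gives > 20000 nM, which is a limit of the assay.
Compound 2 `C#Cc1cn([C@@H]2O[C@H](CO)[C@@H](O)[C@H]2O)c2nc(C)nc(N)c12`: in this assay compound 2 gives > 20000 nM, also a limit of the assay.
Compound 3 `COc1ncnc2c1c(-c1ccccc1)cn2[C@@H]1O[C@H](CO)[C@@H](O)[C@H]1O`: in this assay compound 3 gives > 20000 nM, again a limit of the assay.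

The change from compound 1 to compound 2 is ethynyl in place of phenyl on an aromatic carbon. Its size in this assay is a step that the two limits leave unreadable from compound 1 to compound 2, so the two limits leave it unreadable. The core of compound 3 differs from the core of compound 1, and that difference is not broken down here. Compound 4 `C#Cc1cn([C@@H]2O[C@H](CO)[C@@H](O)[C@H]2O)c2ncnc(OC)c12` differs from compound 3 by ethynyl in place of phenyl on an aromatic carbon, the same change as from compound 1 to compound 2, at a place described in the same words.

What the series shows is the limit of > 20000 nM in this assay, at which 3 of the 3 values shown sit. On that basis the step that the limit leaves unreadable from compound 3 to compound 4 is expected to be unreadable in the same way, because compound 3 sits at the limit > 20000 nM. For compound 4 the estimate in this assay is 25000 nM, expected to lie between 10000 nM and 60000 nM, most likely reported as a limit rather than a number.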

Compound 4, half-maximal inhibitory concentration: 300 nM
Compound 4: middle estimate off by 83-fold (1.92 log units), on the high side; measured number outside the range, below it.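

On the core of compound 3, ethynyl in place of phenyl on an aromatic carbon gives an at least 66-fold lower number from compound 3 to compound 4 (1.82 log units; beyond the scatter) in this assay. On the core of compound 1 the same change ends at compound 2, which gives > 20000 nM, a limit of the assay, and with a limit at both ends that step cannot be read, so it neither confirms nor contradicts the result on the other core. The change therefore has one readable step on one core, and no size can be carried over to the core of compound 1, with most of the series still sitting at a limit: the limit of > 20000 nM in this assay, at which 3 of the 4 values shown sit.

The compounds shown leave open whether a nitrile or a longer chain such as propynyl, on the same aromatic carbon, would keep the number of compound 4 at 300 nM. They also leave open whether a core bearing a carboxylic acid or a dimethylamino group would respond to ethynyl in the same way.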